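Chloro in Place of Methyl: Expecting Compound 4

This account rests on a few compounds, and the source may have more. Where it says the series, first, only, none or still open, it means among the compounds named here.

Compound 1 `C=C(C)C(=O)c1ccc(OCc2nc(-c3ccccc3)no2)cc1C` gives 1970 nM in an assay on HL-60 cells for inhibition of glutathione S-transferase P (Homo sapiens); on this read-out lower numbers stand for stronger inhibition and higher numbers for weaker inhibition.
Compound 2 `C=C(C)C(=O)c1ccc(OCc2nc(-c3ccc(C(F)(F)F)cc3)no2)cc1C` gives 3300 nM.
Compound 3 `C=C(C)C(=O)c1ccc(OCc2nc(-c3ccccc3)no2)c(C)c1C` gives 1800 nM.

Among these three numbers compound 1 stands second highest, with both neighbours within the scatter of it. Compound 4 `C=C(C)C(=O)c1ccc(OCc2nc(-c3ccccc3)no2)cc1Cl` differs from compound 1 by chloro in place of methyl on an aromatic carbon. Among the measured compounds shown here, no measured step exchanges methyl for chloro, so the only guide is the two steps away from compound 1: a 1.7-fold higher number from compound 1 to compound 2 (0.22 log units; within the scatter) and a 1.1-fold lower number from compound 1 to compound 3 (0.04 log units; within the scatter). Both are within the scatter, and a single-atom change of this kind is therefore expected to leave the read-out in this assay without a step beyond the scatter. Compound 4 is expected to give 1900 nM, between 900 nM and 4000 nM, which means a step of a 1.0-fold lower number from compound 1 to compound 4 (0.02 log units; within the scatter).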

Compound 4, half-maximal inhibitory concentration: 600 nM
Beside the measured number, compound 4's estimate is 3.2-fold (0.50 log units) above it; the measured number lies below the stated range.
By their numbers in this assay, from the lowest: compound 4; then compounds 3, 1 and 2 (each within the scatter of the next).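

Chloro in place of methyl, ortho to the (1-methylethenyl)carbonyl group, gives a 3.3-fold lower number from compound 1 to compound 4 (0.52 log units; beyond the scatter) in this assay and is the only single change shown with a step beyond the scatter. This position therefore responds to a one-atom exchange, whereas the changes leading to compound 2 and compound 3 moved the number only within the scatter. Nothing at hand explains why this exchange has such an effect.

As far as these compounds go, whether this is particular to chloro stays open, since bromo, fluoro or methoxy at this position would be needed to tell. From the compounds shown here alone, it is also open whether the same exchange would give a similar step on the core of compound 3.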